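Ortho substituent swap on the aryloxy group of the core

A few compounds are considered here, and "the series" means these few. Any claim that something is new, unique, unknown or untested is made for them only; others in the source may bear on it.

Measured in an assay for inhibition of Thromboxane-A synthase (Homo sapiens), using microsomes; on this read-out higher numbers stand for weaker inhibition and lower numbers for stronger inhibition:
compound 1 `Cc1ccc(C#N)c(OC(C)(C)C2OCC(C/C=C\CCC(=O)O)C(c3cccnc3)O2)c1` gives 50 nM
compound 2 `Cc1ccc(OC(C)(C)C2OCC(C/C=C\CCC(=O)O)C(c3cccnc3)O2)cc1` gives 360 nM
compound 3 `COc1ccccc1OC(C)(C)C1OCC(C/C=C\CCC(=O)O)C(c2cccnc2)O1` gives 60 nM

Compound 3 stands second highest of the three numbers. Its nearest neighbour is compound 1, within the scatter; its furthest is compound 2, beyond the scatter. Compound 4 `CC(C)(Oc1ccccc1Br)C1OCC(C/C=C\CCC(=O)O)C(c2cccnc2)O1` is the next member, not yet measured. The change from compound 3 to compound 4 is bromo in place of methoxy on an aromatic carbon.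

Two of the measured steps bear on this. a 1.2-fold higher number from compound 1 to compound 3 (0.08 log units; within the scatter) shows that exchanging one group ortho to the large group for another leaves the number essentially unchanged. a 6.0-fold lower number from compound 2 to compound 3 (0.78 log units; beyond the scatter) and a 7.2-fold higher number from compound 1 to compound 2 (0.86 log units; beyond the scatter) show that the compound lacking any group ortho to the large group, compound 2, sits modestly weaker than either compound carrying one. Among the measured compounds shown here, no measured step covers bromo itself, so its own contribution is unknown.

Compound 4 keeps a group ortho to the large group, so in this assay a step of about a 1.2-fold higher number from compound 3 to compound 4 (0.07 log units; within the scatter) is expected, that is, no shift beyond the scatter in either direction. The estimate for compound 4 is 70 nM, with a range from 30 nM to 200 nM.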

Compound 4, half-maximal inhibitory concentration: 29 nM
Beside the measured number, compound 4's estimate is 2.4-fold (0.38 log units) above it, outside the stated range (below it).
By their numbers in this assay, from the lowest: compounds 4, 1 and 3 (each within the scatter of the next, the first and the last beyond it); then compound 2.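

Working notes: the identity of the group ortho to a large group matters in this assay, since bromo in place of methoxy gives a 2.1-fold lower number from compound 3 to compound 4 (0.32 log units; beyond the scatter), whereas the earlier exchange between compound 1 and compound 3 left the number within the scatter. Among the compounds shown here, the series now also holds a large step, a 12-fold lower number from compound 2 to compound 4 (1.09 log units; beyond the scatter), which widens the gap between the only compound lacking a group at this place and those carrying one; all three that carry one have lower numbers than compound 2, and none goes against this, although a 1.7-fold lower number from compound 1 to compound 4 (0.24 log units; within the scatter) stays within the scatter and leaves compound 1 and compound 4 unordered. Nothing available here explains why the bromo compound differs from the methoxy compound.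

Still open, as far as these compounds go, is whether fluoro, chloro, iodo or an amine at this same place would follow bromo or methoxy in this assay. For the compounds shown here, compound 2 is also the only compound with 4-methylphenyl, so the effect of a missing group at this place cannot be separated from that of its methyl, and a plain phenyl would be the direct comparison.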